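Compound 2 to compound 4: loss of tert-butoxycarbonyl

A few compounds are considered here, and "the series" means these few. Any claim that something is new, unique, unknown or untested is made for them only; others in the source may bear on it.

Among the compounds with values here, in a functional assay on LNCaP cells (Homo sapiens) for cytotoxicity, read by MTT assay, with a stated time of 72 h (a higher number here means a weaker inhibitor, a lower number a stronger inhibitor), compound 1 (`N[C@H]1CC[C@H](Nc2c(C(=O)NCc3ccc(F)cc3)nc(N3CCCCS3(=O)=O)c3cccnc23)CC1`) gives 8000 nM as the only plain number. For compound 3 (`N[C@H]1CC[C@H](Nc2c(C(=O)NCc3ccc(F)cc3)nc(N3CCCCC3)c3cccnc23)CC1`) the entry is "not determined" (no result reported). Compound 2 (`CC(C)(C)OC(=O)N1CCN(c2c(C(=O)NCc3ccc(F)cc3)nc(Br)c3cccnc23)CC1`) stands at > 10000 nM here, which is a limit of the assay and not a number. Compound 4 (`O=C(NCc1ccc(F)cc1)c1nc(Br)c2cccnc2c1N1CCNCC1`) carries hydrogen in place of tert-butoxycarbonyl on an amine nitrogen in a ring. Within the data shown here, no measured step covers this change, so the guide is thin: compound 1 at 8000 nM is the sole reading, and it also lacks tert-butoxycarbonyl. The expected at least 1.6-fold lower number from compound 2 to compound 4 (0.22 log units; that floor lies within the scatter) is a modest move toward stronger inhibition in this assay and no more. For compound 4 the estimate is 6000 nM within an expected range from 1500 nM to 12000 nM in this series.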

Compound 4, half-maximal inhibitory concentration: 4500 nM
Compound 4: middle estimate off by 1.3-fold (0.12 log units), on the high side; measured number inside the range.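

In this assay, hydrogen in place of tert-butoxycarbonyl on the amine nitrogen in the ring gives an at least 2.2-fold lower number from compound 2 to compound 4 (0.34 log units; beyond the scatter), the only step shown at this position. The size of that step is a floor, and compound 2 enters it only as a limit of the assay, not as a number: the limit of > 10000 nM in this assay, at which 1 of the 4 values shown sits.

The compounds shown leave open how a methyl or acetyl group on that nitrogen would read against the hydrogen of compound 4. Also open, on these data alone, is whether the step would hold with an amine in place of the bromine.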